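The source may hold more compounds than are shown below. What is called first, only, known or untested is meant among the compounds shown, and "the series" means these compounds.

Three compounds have been measured in a functional assay on MDA-MB-231 cells (Homo sapiens) for inhibition, read by MTT assay, with a stated time of 72 h; a lower number here means a stronger inhibitor, a higher number a weaker inhibitor:

Compound 1, `O=C(CSc1nc(Nc2ccccc2)c2ccccc2n1)Nc1cccc(Cl)c1`: 16500 nM
Compound 2, `O=C(CSc1nc(Nc2ccccc2)c2ccccc2n1)Nc1cccc(Br)c1`: 17500 nM
Compound 3, `C=CC(=O)Nc1cccc(NC(=O)CSc2nc(Nc3ccccc3)c3ccccc3n2)c1`: 10200 nM

Compound 3 gives the lowest of the three numbers, but its gaps to the others are small: a 1.6-fold lower number from compound 1 to compound 3 (0.21 log units; within the scatter) and a 1.7-fold lower number from compound 2 to compound 3 (0.23 log units; within the scatter), so the three cannot be ordered. Among the measured compounds shown here, the one halogen swap on record, a 1.1-fold higher number from compound 1 to compound 2 (0.03 log units; within the scatter), is likewise small.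

Compound 4, `C=CC(=O)Nc1cccc(NC(=O)CSc2nc(Nc3ccccc3Br)c3ccccc3n2)c1`, differs from compound 3 by bromo in place of hydrogen on an aromatic carbon. For the measured compounds named here, no measured step touches that ring of the shared core; the only bromine change recorded, from compound 1 to compound 2, sits on the other aryl ring and was within the scatter. Going by the values given here, with no step pointing either way, compound 4 is expected to give a number close to that of compound 3, and the estimated step of a 1.0-fold lower number from compound 3 to compound 4 (0.01 log units; within the scatter) is taken as no change beyond the scatter. Compound 4 is therefore estimated at 10000 nM, within a range from 4000 nM to 25000 nM.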

Compound 4, half-maximal inhibitory concentration: 15200 nM
Compound 4: the middle estimate sits 1.5-fold (0.18 log units) below what was measured, within the range that was stated.
By their numbers in this assay, from the lowest: compounds 3, 4, 1 and 2 (each within the scatter of the next).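

In this assay, among the compounds shown here, compound 4 gives the first reading for a substituent on the anilino ring of the shared core: phenyl to 2-bromophenyl, with the bromo ortho to a large group, gives a 1.5-fold higher number from compound 3 to compound 4 (0.17 log units; within the scatter). The earlier compounds shown here varied only the other aryl ring, so this shows that a single bromine atom at this new place, with the (vinylcarbonyl)amino group kept, also leaves no difference that can be told from the scatter. Nothing available explains this reading or shows how the bromo acts at this position.

Still open, going by these compounds, is whether a methoxy, an amine or a carboxylic acid on this ring would give a number beyond the scatter. On these data alone, it is also open whether bromo elsewhere on the ring would read as the 2-bromophenyl does.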